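This account rests on a few compounds, and the source may have more. Where it says the series, first, only, none or still open, it means among the compounds named here.

In a functional assay on PC-9 cells (Homo sapiens) for inhibition, read by MTT assay, with a stated time of 72 h (a lower number here means a stronger inhibitor, a higher number a weaker inhibitor), compound 1 `Cc1cc(Nc2cc(-c3ccccc3)[nH]n2)n2nc(SCc3ccc(F)cc3)nc2n1` gives 8110 nM, compound 2 `Cc1cc(Nc2cc(-c3ccccc3)[nH]n2)n2nc(SCc3ccccc3Br)nc2n1` gives 5630 nM and compound 3 `Cc1cc(Nc2cc(-c3ccccc3)[nH]n2)n2nc(SCCCc3ccccc3)nc2n1` gives 5030 nM. These values sit so close together that compound 3 has no clear rank among them. Compound 4 `Cc1cc(Nc2cc(-c3ccccc3)[nH]n2)n2nc(SCc3nc4ccccc4[nH]3)nc2n1` carries 1H-benzimidazol-2-yl in place of phenethyl on a saturated chain carbon bound to a sulfur. Among the measured compounds shown here, the only guides are the measured changes at this same place, namely a 1.4-fold lower number from compound 1 to compound 2 (0.16 log units; within the scatter), a 1.6-fold lower number from compound 1 to compound 3 (0.21 log units; within the scatter) and a 1.1-fold lower number from compound 2 to compound 3 (0.05 log units; within the scatter). With these as a guide, no step beyond the scatter is expected in this assay, although none of compounds 1 to 3 carries a five-membered aromatic ring with 2 hetero atoms there, so the guide is a loose one. The expected step is a 1.1-fold lower number from compound 3 to compound 4 (0.05 log units; within the scatter). For compound 4 the estimated value is 4500 nM, with an expected range of 1500 nM to 12000 nM.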

Compound 4, half-maximal inhibitory concentration: 4840 nM
Compound 4: the middle estimate sits 1.1-fold (0.03 log units) below what was measured; the range from low to high includes it.
By their numbers in this assay, from the lowest: compounds 4, 3, 2 and 1 (each within the scatter of the next).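

In this assay, 1H-benzimidazol-2-yl brings a five-membered aromatic ring with 2 hetero atoms to this place, which the groups of compounds 1 to 3 lack, yet every step stays within the scatter: (a 1.0-fold lower number from compound 3 to compound 4 (0.02 log units; within the scatter)), (a 1.2-fold lower number from compound 2 to compound 4 (0.07 log units; within the scatter)) and (a 1.7-fold lower number from compound 1 to compound 4 (0.22 log units; within the scatter)). On a saturated chain carbon bound to a sulfur, this change of ring type therefore leaves the number unmoved in all three comparisons. No measurement here explains this. On these data alone, whether an amine or a carboxylic acid at this place would give a step beyond the scatter remains open.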